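The source may report more compounds than this note shows. Statements on the series, on what has been measured and on what is new or still open speak of the compounds shown alone.

Three compounds share one core and differ only in the aryl group on an aromatic nitrogen. Compound 1 `Cc1cc(=O)n(-c2cccc(F)c2)nc1C(=O)Nc1ccc(Oc2ncnc3[nH]ccc23)cc1` gives 34800 nM in a functional assay on A549 cells (Homo sapiens) for cytotoxicity, read by MTT assay, with a stated time of 72 h; on this read-out higher numbers stand for weaker inhibition and lower numbers for stronger inhibition. Compound 2 `Cc1ccc(-n2nc(C(=O)Nc3ccc(Oc4ncnc5[nH]ccc45)cc3)c(C)cc2=O)cc1` gives 6400 nM in this assay, and compound 3 `Cc1cc(=O)n(-c2ccc(Br)cc2F)nc1C(=O)Nc1ccc(Oc2ncnc3[nH]ccc23)cc1` gives 3770 nM in this assay. Compound 3 thus shows the lowest number of the three, though its gap to compound 2 lies within the scatter; only its gap to compound 1 lies beyond it. Compound 4 `Cc1cc(=O)n(-c2cccc(C(F)(F)F)c2)nc1C(=O)Nc1ccc(Oc2ncnc3[nH]ccc23)cc1` is the next step: 3-(trifluoromethyl)phenyl in place of 4-bromo-2-fluorophenyl on an aromatic nitrogen. Within the data shown here, no measured step covers this change directly. Among the measured compounds shown here, the steps that bear on it are a 5.4-fold lower number from compound 1 to compound 2 (0.74 log units; beyond the scatter) and a 9.2-fold lower number from compound 1 to compound 3 (0.97 log units; beyond the scatter), both modest and both starting from compound 1, whose 3-fluorophenyl most resembles the 3-(trifluoromethyl)phenyl entering compound 4. Since compound 1 gave 34800 nM, the return to a group of that kind is expected to move the number upward, by an estimated 2.4-fold higher number from compound 3 to compound 4 (0.38 log units; beyond the scatter). Compound 4 is therefore expected to give about 9000 nM in this assay, within a range from 3000 nM to 30000 nM.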

Compound 4, half-maximal inhibitory concentration: 7570 nM
Compound 4: middle estimate off by 1.2-fold (0.08 log units), on the high side; the range from low to high includes it.
By their numbers in this assay, from the lowest: compounds 3, 2 and 4 (each within the scatter of the next); then compound 1.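

Trifluoromethyl in place of fluoro on an aromatic carbon gives a 4.6-fold lower number from compound 1 to compound 4 (0.66 log units; beyond the scatter) in this assay, so the high number of compound 1 does not extend to every aryl group of its kind. The other two steps, a 2.0-fold higher number from compound 3 to compound 4 (0.30 log units; within the scatter) and a 1.2-fold higher number from compound 2 to compound 4 (0.07 log units; within the scatter), stay within the scatter, so 3-(trifluoromethyl)phenyl, 4-bromo-2-fluorophenyl and 4-methylphenyl cannot be told apart here, while compound 1 alone stands apart from all three. Nothing available explains this difference between the fluoro compound and the others.

On these data alone, whether an amine, a carboxylic acid or a methoxy group on this aryl ring would stay with the three closer compounds or fall nearer compound 1 remains open. The same holds for an unsubstituted phenyl and for a replacement of the aryl group by a longer alkyl chain.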